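A few compounds are considered here, and "the series" means these few. Any claim that something is new, unique, unknown or untested is made for them only; others in the source may bear on it.

In a toxicity assay on HEK-293T cells (Homo sapiens) for inhibition, read by MTT assay, with a stated time of 24 h (on this read-out higher numbers stand for lower toxicity in this test and lower numbers for higher toxicity in this test), compound 1 (`O=c1oc2ccccc2c(N2CCN(c3ccccc3)CC2)c1CO`) gives > 50000 nM as its reading, a limit of the assay and not a number. Compound 2 (`O=c1oc2ccccc2c(N2CCN(C(c3ccccc3)c3ccc(Cl)cc3)CC2)c1CO`) gives > 50000 nM as its reading, again a limit. Where compound 1 stands is therefore known only as a limit (the limit of > 50000 nM in this assay, at which 2 of the 2 values shown sit) and not as an exact value. Compound 3 (`O=c1oc2ccccc2c(N2CCN(c3ccc(Cl)c(Cl)c3)CC2)c1CO`) has 3,4-dichlorophenyl in place of phenyl on an amine nitrogen in a ring. For the measured compounds named here, no measured pair shows what such a change does in this assay so any expectation is loose. It leans on compound 2, which carries another group on the same nitrogen and still gives > 50000 nM as a limit. The expected step is small, within the usual scatter or a modest move toward lower numbers and so higher toxicity (a number no higher from compound 1 to compound 3 (the limit leaves the size open) is the estimate). For compound 3 the estimated value is 50000 nM with an expected range from 20000 nM to 100000 nM and the reading may well again be only a limit.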

Compound 3, half-maximal cytotoxic concentration: > 50000 nM
Compound 3: only a limit was reported (the forecaster's own chance of this, stated with the estimate: 70%); the middle value sits exactly at the limit.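

Compound 1 and compound 3 both give only a limit in this assay, so no step between them can be read: the limit of > 50000 nM in this assay, at which 3 of the 3 values shown sit.

The compounds shown leave open the exact readings of all three and whether swapping the group on that ring nitrogen changes toxicity in this test at all.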